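Working notes on compounds 1 to 4

The compounds below may be only part of what the source reports. "The series", "measured", "known", "first", "only" and "open" are said of these compounds alone.

Measured so far:
compound 1 `CCOC(=O)C(C)C(O)(c1ccc(OC)c(OC)c1OC)c1cccc2ccccc12`, 4000 nM
compound 2 `COc1cc(COC(c2ccc(OC)c(OC)c2OC)c2cccc3ccccc23)cc(OC)c1`, 17500 nM
compound 3 `COc1ccc(C(OCc2ccccc2)c2cccc3ccccc23)c(OC)c1OC`, 13500 nM

In a functional assay on A549 cells (Homo sapiens) for inhibition, read by sulforhodamine B assay, with a stated time of 48 h (a lower number here means a stronger inhibitor, a higher number a weaker inhibitor), compound 1 gives the lowest number of the three; compound 3 sits higher and compound 2 higher still, both beyond the scatter. Compound 4 `COc1ccc(C(O)(Cc2ccccc2)c2cccc3ccccc23)c(OC)c1OC` differs from compound 1 in one place: benzyl in place of 1-(ethoxycarbonyl)ethyl on a saturated chain carbon bound to two aromatic carbons and an oxygen on a saturated carbon. Among the compounds with values here, the only measured single-point step, a 1.3-fold lower number from compound 2 to compound 3 (0.11 log units; within the scatter), concerns a different place on a different pair and does not bear on this change. Within the data shown here, no measured pair shows what replacing 1-(ethoxycarbonyl)ethyl by benzyl does, so the expected step of a 1.3-fold higher number from compound 1 to compound 4 (0.10 log units; within the scatter) rests on compound 1 alone, with no direction claimed beyond the scatter. Compound 4 is therefore estimated at 5000 nM, within a range from 1500 nM to 16000 nM.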

Compound 4, half-maximal inhibitory concentration: > 20000 nM
Compound 4: only a limit was reported; the forecaster's own chance of this, stated with the estimate: 10%; middle value at least 4.0-fold (0.60 log units) away from the limit.
By their numbers in this assay, from the lowest: compound 1; then compounds 3 and 2 (each within the scatter of the next). At a limit, above all of these: compound 4.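

In this assay, the group on a saturated chain carbon bound to two aromatic carbons and an oxygen on a saturated carbon proves to matter: benzyl in place of 1-(ethoxycarbonyl)ethyl gives an at least 5.0-fold higher number from compound 1 to compound 4 (0.69 log units; beyond the scatter). The reading for compound 4 is a limit and not a number, so the step has a floor but no measured size: the limit of > 20000 nM in this assay, at which 1 of the 4 values shown sits. Which part of 1-(ethoxycarbonyl)ethyl carries the difference remains open. A carboxylic acid or an amide at this place would separate the ester from the chain.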